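A few compounds are considered here, and "the series" means these few. Any claim that something is new, unique, unknown or untested is made for them only; others in the source may bear on it.

Measured so far in this series:
- compound 1 `O=C(c1ccncc1)N1N=C(c2cc3ccccc3o2)CC1c1ccc(O)cc1`, which in an ADME assay on Vero cells (Chlorocebus sabaeus) for cytotoxicity, read by MTT assay, with a stated time of 72 h (on this read-out lower numbers stand for stronger inhibition and higher numbers for weaker inhibition), gives > 200000 nM, a limit of the assay.
- compound 2 `O=C(c1ccncc1)N1N=C(c2cc3ccccc3o2)CC1c1ccccc1Cl`, which in this assay gives > 210000 nM, also a limit.
- compound 3 `O=C(c1ccncc1)N1N=C(c2cc3ccccc3o2)CC1c1ccccc1`, which in this assay gives > 209000 nM, again a limit.

Compound 3 stands at a limit (the limit of > 209000 nM in this assay, at which 1 of the 3 values shown sits). The two other values shown are limits as well the limit of > 200000 nM in this assay, at which 1 of the 3 values shown sits (the limit of > 210000 nM in this assay, at which 1 of the 3 values shown sits). Accordingly the steps a step that the two limits leave unreadable from compound 1 to compound 2, a step that the two limits leave unreadable from compound 1 to compound 3 and a step that the two limits leave unreadable from compound 2 to compound 3 cannot be read as sizes. Compound 4 `O=C(c1ccncc1)N1N=C(c2cc3ccccc3o2)CC1/C=C/c1ccccc1` differs from compound 3 by 2-phenylethenyl in place of phenyl on a saturated ring carbon. Among the measured compounds shown here, no measured step gives a readable size, so there is no ground to expect a step beyond the scatter in this assay. Compound 4 is expected to sit at a limit again, estimated at 200000 nM, between 100000 nM and 400000 nM. The expected step of an at least 1.0-fold lower number from compound 3 to compound 4 (0.01 log units; that floor lies within the scatter) is none beyond the scatter.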

Compound 4, half-maximal inhibitory concentration: > 212000 nM
Compound 4 gave a limit, no number; the forecaster's own chance of this, stated with the estimate: 85%; middle value at least 1.0-fold (0.02 log units) from the limit.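

In this assay compound 4 gives > 212000 nM, a limit of the assay. Among the compounds shown here, no step from compound 1, compound 2 or compound 3 to compound 4 can be read, since all four values are limits. The compounds shown leave open what number any of them would reach in this assay.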